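A few compounds are considered here, and "the series" means these few. Any claim that something is new, unique, unknown or untested is made for them only; others in the source may bear on it.

Measured compounds:
- compound 1, `C[Se]/C(=N\C(=O)c1cc2ccccc2s1)NC(=O)c1cc2ccccc2s1`: 73300 nM
- compound 2, `C[Se]/C(=N\C(=O)c1cccs1)NC(=O)c1cccs1`: 12500 nM

Both compounds were tested in a functional assay on HepG2 cells (Homo sapiens) for cytotoxicity, read by MTT assay, with a stated time of 72 h; on this read-out higher numbers stand for lower toxicity in this test and lower numbers for higher toxicity in this test. On this read-out compound 1 gives 73300 nM, while compound 2 gives 12500 nM, the lower of the two numbers, and the gap between them is beyond the usual scatter, so compound 2 is the more toxic of the two measured compounds. Among the compounds with values here, compound 1 and compound 2 differ in their ring systems, and no single-change step between them is available, so only their two values can be compared.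

Compound 3, `O=C(/N=C(/NC(=O)c1cccs1)[Se]Cc1ccccc1)c1cccs1`, has not yet been measured. It differs from compound 2 in one place: phenyl in place of hydrogen on a saturated chain carbon bound to a selenium atom. Whether this change alters toxicity cannot be read from the two measured compounds, since neither shows the effect of enlarging the group on selenium. With no direct guide, the expected step from compound 2 to compound 3 in this assay is a 1.6-fold lower number from compound 2 to compound 3 (0.19 log units; within the scatter), a change expected to stay within or close to the scatter. Compound 3 is therefore expected to give about 8000 nM in this assay, within a range from 3000 nM to 25000 nM.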

Compound 3, concentration lethal to 50% of the cells: 81500 nM
Estimate against measurement, compound 3: 10-fold (1.01 log units) below; measured number outside the range, above it.
By their numbers in this assay, from the lowest: compound 2; then compounds 1 and 3 (each within the scatter of the next).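

In this assay the group on selenium proves to matter, as going from methyl to benzyl gives a 6.5-fold higher number from compound 2 to compound 3 (0.81 log units; beyond the scatter) and this step lies beyond the scatter. Higher numbers here stand for lower toxicity in this test, so placing phenyl on the saturated chain carbon bound to a selenium atom makes the compound less toxic in these cells, which the earlier pair could not show: those two differ in their ring systems and both carry methyl on selenium. No measurement at hand accounts for this change, so the result stands as an observation without an explanation.

This single step cannot separate the contribution of the phenyl ring from that of a larger carbon group in general, and a longer chain such as propyl on selenium, or a benzyl group carrying an amine or a carboxylic acid on its ring, would test that distinction. As far as these compounds go, it also remains open whether going from methyl to benzyl would move the number in the same direction and by a similar amount on the core of compound 1.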